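Methoxy for Fluoro on the Hydrazone Aryl Ring

A few compounds are considered here, and "the series" means these few. Any claim that something is new, unique, unknown or untested is made for them only; others in the source may bear on it.

Compound 1 `CN(C)CCn1cnnc1-c1cc(Oc2ccc(NC(=O)N/N=C/c3ccc(F)cc3F)cc2F)ccn1`: 1870 nM
Compound 2 `CN(C)CCn1cnnc1-c1cc(Oc2ccc(NC(=O)N/N=C/c3ccc(O)c(F)c3)cc2F)ccn1`: 13400 nM

Both compounds share one core and differ only in the aryl ring attached to the carbon with a double bond to nitrogen. In a functional assay on A549 cells (Homo sapiens) for cytotoxicity, read by MTT assay, with a stated time of 72 h (a higher number here means a weaker inhibitor, a lower number a stronger inhibitor), compound 2 gives 13400 nM, the highest of the two numbers; its nearest neighbour is compound 1, and the step of a 7.2-fold higher number from compound 1 to compound 2 (0.86 log units; beyond the scatter).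

Compound 3 `COc1cc(/C=N/NC(=O)Nc2ccc(Oc3ccnc(-c4nncn4CCN(C)C)c3)c(F)c2)ccc1O` is not yet measured. It differs from compound 2 by methoxy in place of fluoro on an aromatic carbon, so the hydroxy group is kept and only its neighbour on the ring is exchanged. For the measured compounds named here, no measured step involves a methoxy group, and the one step known, a 7.2-fold higher number from compound 1 to compound 2 (0.86 log units; beyond the scatter), concerns a larger exchange of the whole ring. Compound 3 is therefore expected to stay close to compound 2, with a step of a 1.1-fold higher number from compound 2 to compound 3 (0.05 log units; within the scatter) that may well fall within the scatter. The estimate for compound 3 in this assay is 15000 nM, between 5000 nM and 45000 nM.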

Compound 3, half-maximal inhibitory concentration: > 100000 nM
Compound 3: no number, only a limit; the forecaster's own chance of this, stated with the estimate: 10%; middle value at least 6.6-fold (0.82 log units) from the limit.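

The value for compound 3 in this assay is a limit of the assay and not a number: the limit of > 100000 nM in this assay, at which 1 of the 3 values shown sits. Even so, this position proves sensitive to a small exchange, with the hydroxy group kept, as swapping fluoro for methoxy alone gives an at least 7.4-fold higher number from compound 2 to compound 3 (0.87 log units; beyond the scatter). Measured against the 2,4-difluorophenyl ring, the whole-ring exchange gives an at least 53-fold higher number from compound 1 to compound 3 (1.72 log units; beyond the scatter), so the earlier picture of a ring change costing only a modest amount does not hold for every ring.

How far the true number for compound 3 lies beyond the limit stays unknown, and these values give no cause for the loss. From the compounds shown here alone, whether the loss is particular to methoxy also stays open, and an ethoxy group, a chlorine or an amine on that same aromatic carbon would help to test it.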